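The compounds below may be only part of what the source reports. "The series", "measured", "known", "first", "only" and "open" are said of these compounds alone.

Of the compounds shown here, three built on one shared core have been tested in a functional assay on a cell-free system (plasma) for inhibition of platelet-activating factor acetylhydrolase (Homo sapiens), tested at 100 nM; a higher number here means more inhibition at the concentration tested (going by the name of the read-out), a lower number less inhibition. Compound 1 `CCCCCCCCN(C)C(=O)Cn1cc(Cc2cnc(=O)n(C)c2)c(=O)nc1SCc1ccc(F)cc1` gives 55%, compound 2 `CCCCCCCCN(C)C(=O)Cn1cc(Cc2cnc(=O)n(CCO)c2)c(=O)nc1SCc1ccc(F)cc1` gives 59%, and compound 3 `CCCCCCCCCCCCN(C)C(=O)Cn1cc(Cc2cnc(=O)n(CC(=O)OCC)c2)c(=O)nc1SCc1ccc(F)cc1` gives 55%. Compound 3 therefore stands level with compound 1, and compound 2 lies within the scatter of both. Among the compounds with values here, the one single-point step measured so far, hydroxymethyl in place of hydrogen on a saturated chain carbon bound to an aromatic nitrogen, gave a number 4 percentage points higher from compound 1 to compound 2 (within the scatter). Compound 4 `CCCCCCCCCCCCN(C)C(=O)Cn1cc(Cc2cnc(=O)n(CCO)c2)c(=O)nc1SCc1ccc(F)cc1` differs from compound 3 by hydroxymethyl in place of ethoxycarbonyl on a saturated chain carbon bound to an aromatic nitrogen. Within the data shown here, that is not the same exchange, but the only nearby evidence shows no movement beyond the scatter, so no step beyond the scatter is expected here either. Compound 4 is estimated at 57%, between 45% and 69%. The expected step is a number 2 percentage points higher from compound 3 to compound 4 (within the scatter).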

Compound 4, a percentage reported as inhibition, at one concentration (the size of the read-out at that concentration, not a potency): 77%
Estimate against measurement, compound 4: 20 percentage points below; the whole stated range lies below it.
By their numbers in this assay, from the lowest: compounds 1, 3 and 2 (each within the scatter of the next); then compound 4.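

This position can move the read-out after all: in this assay, exchanging ethoxycarbonyl for hydroxymethyl on the long-chain compounds gives a clear gain (a number 22 percentage points higher from compound 3 to compound 4 (beyond the scatter)). With hydroxymethyl in place, adding butyl to the chain also counts (a number 18 percentage points higher from compound 2 to compound 4 (beyond the scatter)), so compound 4 stands clear of compounds 2 and 3. Nothing available explains either step.

Still open, going by these compounds, is how an amine or a carboxylic acid in place of the hydroxymethyl would read. Whether a still longer chain would add further inhibition also remains unanswered.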